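The source may report more compounds than this note shows. Statements on the series, on what has been measured and on what is new or still open speak of the compounds shown alone.

Of the compounds shown here, three sharing one core have been tested in an ADME assay on the whole organism (lung, Rattus norvegicus) for metabolic stability, read by LC-MS; a lower number here means that the compound disappears faster, a higher number that the compound lasts longer. Compound 1 `Cc1csc2cc([C@H](C)Nc3ncnc(N)c3C#N)c(-c3cccc(CN4CCC(N(C)CC(C)C)CC4)c3)c(=O)n12` gives 9.9 h. Compound 2 `Cc1csc2cc([C@H](C)Nc3ncnc(N)c3C#N)c(-c3cccc(CN(C)CCCCN(C)Cc4ccccc4)c3)c(=O)n12` gives 17.6 h. Compound 3 `Cc1csc2cc([C@H](C)Nc3ncnc(N)c3C#N)c(-c3cccc(CN(C)CCCN(C)Cc4ccc(Cl)cc4)c3)c(=O)n12` gives 13 h. The numbers of compound 3 and compound 1 lie within the usual scatter of each other, as do those of compound 3 and compound 2, so none of the three can be called more stable than another.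

Going by the values given here, the only step that touches the same place is a 1.4-fold lower number from compound 2 to compound 3 (0.13 log units; within the scatter), a change that stayed within the scatter. Compound 4 `Cc1csc2cc([C@H](C)Nc3ncnc(N)c3C#N)c(-c3cccc(CN(C)CCCN4C[C@@H](C)O[C@@H](C)C4)c3)c(=O)n12` differs from compound 3 by 2,6-dimethylmorpholin-4-yl in place of (4-chlorobenzyl)(methyl)amino on a saturated chain carbon, three bonds along the chain from an amine nitrogen. Among the compounds with values here, no measured step swaps an amine bearing an aromatic ring for a saturated ring of this kind, so the expectation rests on the single nearby step, which was small. The step from compound 3 to compound 4 is therefore expected to be a 1.3-fold lower number from compound 3 to compound 4 (0.11 log units; within the scatter), not clearly beyond the scatter in either direction. Compound 4 is estimated at 10 h in this assay, with a plausible range from 5 h to 20 h.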

Compound 4, half-life: 5.9 h
The estimate for compound 4 lay 1.7-fold (0.23 log units) above the measured number, within the range that was stated.
By their numbers in this assay, from the lowest: compounds 4, 1, 3 and 2 (each within the scatter of the next, the first and the last beyond it).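

In this assay the end of this chain can move the number: 2,6-dimethylmorpholin-4-yl in place of (4-chlorobenzyl)(methyl)amino gives (a 2.2-fold lower number from compound 3 to compound 4 (0.34 log units; beyond the scatter)), and in place of (benzyl(methyl)amino)methyl it gives (a 3.0-fold lower number from compound 2 to compound 4 (0.47 log units; beyond the scatter)), both beyond the scatter. Going by these compounds alone, the earlier step between two amines that each carry a benzyl group (a 1.4-fold lower number from compound 2 to compound 3 (0.13 log units; within the scatter)) stayed within the scatter, so the first change to leave it is one that removes the aromatic ring and brings in a non-aromatic ring holding oxygen. No measurement at hand explains this shorter half-life.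

Which part of the change goes with the shorter half-life stays open. A morpholin-4-yl without the two methyl groups, or a piperidin-1-yl without the ring oxygen, on the same chain would help to separate these parts.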